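A few compounds are considered here, and "the series" means these few. Any claim that something is new, unique, unknown or untested is made for them only; others in the source may bear on it.

Working notes, toxicity side of the series. The read-out followed is a toxicity assay on THP-1 cells (Homo sapiens) for inhibition; on this read-out higher numbers stand for lower toxicity in this test and lower numbers for higher toxicity in this test. Compound 1 `Cn1c(-c2ccc(C#N)cc2)cnc1NC(=O)c1ncc[nH]1` is reported only as a limit of this assay, > 100000 nM. Compound 2 `Cn1c(-c2ccc(C#N)cc2)cnc1NC(=O)c1ccc(F)cc1` is likewise reported as a limit, > 50000 nM. Compound 3 `O=C(Nc1ncc(-c2ccccc2)o1)c1ccc(F)cc1`, on a different core, gives a number in this assay, 17000 nM. For the measured compounds named here, the single step between measured compounds that differ in one place is a step that the two limits leave unreadable from compound 1 to compound 2; its size cannot be read because of the limit of > 100000 nM in this assay, at which 1 of the 3 values shown sits, and (the limit of > 50000 nM in this assay, at which 1 of the 3 values shown sits). Compound 2 therefore stands at one of the two limits shown, with no numbered neighbour on its own core.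

Compound 4 `Cc1cccc(-c2cnc(NC(=O)c3ccc(F)cc3)n2C)c1` differs from compound 2 in one place: 3-methylphenyl in place of 4-cyanophenyl on an aromatic carbon. Going by the values given here, no measured step touches this position; the one measured step concerns the carbonyl side and is itself unreadable, so nothing of known size carries over. Among the compounds with values here, the only orientation is that compound 3, the sole numbered value, sits at the lower end of the set while both compounds on the shared core of compound 2 sit at limits. Compound 4 is therefore expected to stay in the low-toxicity region, with a likely outcome of a limit again, and the step of a number no higher from compound 2 to compound 4 (the limit leaves the size open) is expected to be none beyond the scatter. Compound 4 is estimated at 50000 nM, in the range 15000 nM to 150000 nM.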

Compound 4, half-maximal cytotoxic concentration: > 100000 nM
Compound 4 was reported as a limit; the forecaster's own chance of this, stated with the estimate: 55%; middle value at least 2.0-fold (0.30 log units) from the limit.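

No new step can be read between compound 2 and compound 4 because both stand only at limits, compound 4 at the first and compound 2 at the second of these: the limit of > 100000 nM in this assay, at which 2 of the 4 values shown sit; (the limit of > 50000 nM in this assay, at which 1 of the 4 values shown sits). The compounds shown leave open whether 3-methylphenyl in place of 4-cyanophenyl shifts the result in this assay at all.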